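The source may hold more compounds than are shown below. What is called first, only, known or untested is meant among the compounds shown, and "the series" means these compounds.

Measured so far:
- In a functional assay on the whole organism for inhibition, with Rattus norvegicus as the target, at a dose of 30 mg/kg (on this read-out lower numbers stand for less inhibition and higher numbers for more inhibition at the one dose given (going by the name of the read-out)), compound 1 `N#Cc1ccccc1-c1nc2cccnc2o1` gives 61%.
- In this assay compound 2 `O=[N+]([O-])c1ccc(-c2nc3cccnc3o2)cc1` gives 5%.

Compound 1 stands highest of the two numbers; compound 2 sits far below it, a gap well beyond the usual scatter. Among the measured compounds shown here, the two compounds share the same core and differ in the group on the benzene ring and in where that group sits, so no single step links them, and their two values only show that one arrangement gives strong inhibition and the other almost none.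

Compound 3 `O=[N+]([O-])c1ccccc1-c1nc2cccnc2o1` is not yet measured. It differs from compound 1 by nitro in place of cyano on an aromatic carbon. For the measured compounds named here, with no measured step of this exact kind to lean on, the expectation for this assay rests on compound 1 alone, together with the low value of compound 2, which carries the same nitro group though in another place. A step downward of moderate size is expected, with wide uncertainty in both directions. The expected change is a number 26 percentage points lower from compound 1 to compound 3 (beyond the scatter). For compound 3 the estimate is 35%, within a range from 5% to 65%.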

Compound 3, a percentage reported as inhibition, in the whole organism at one dose (the size of the read-out at that dose, not a potency): 57%
Beside the measured number, compound 3's estimate is 22 percentage points below it; measured number inside the range.
By their numbers in this assay, from the lowest: compound 2; then compounds 3 and 1 (each within the scatter of the next).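

Putting nitro in place of cyano at this position, ortho to a group of 9 heavy atoms, gives a number 4 percentage points lower from compound 1 to compound 3 (within the scatter) in this assay and so leaves the read-out unchanged within the usual spread of repeat measurements. Carrying a nitro group therefore does not by itself go with a value as low as the one for compound 2 at 5% in this assay, as compound 3 carries the same group. No measurement here explains why the two groups give such similar numbers.

Still open, on these data alone, is what other groups at this position would give, such as an amine, a carboxylic acid or a longer chain. Also open, as far as these compounds go, is what cyano would give at the place the nitro group holds in compound 2.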